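Benzylthio series on the nucleoside core: outlook for compound 3

This account rests on a few compounds, and the source may have more. Where it says the series, first, only, none or still open, it means among the compounds named here.

Measured so far:
compound 1 `OC[C@H]1O[C@@H](n2cnc3c(SCc4ccc(Br)cc4)ncnc32)[C@H](O)[C@@H]1O` — 11.5 nM
compound 2 `OC[C@H]1O[C@@H](n2cnc3c(SCc4cccc(C(F)(F)F)c4)ncnc32)[C@H](O)[C@@H]1O` — 19.1 nM

In an assay on isolated protein for inhibition of Equilibrative nucleoside transporter 1 (Homo sapiens) (on this read-out higher numbers stand for weaker inhibition and lower numbers for stronger inhibition), compound 2 gives 19.1 nM and compound 1 gives 11.5 nM; the step of a 1.7-fold higher number from compound 1 to compound 2 (0.22 log units; within the scatter) lies within the scatter, so the two stand level. Compound 3 `Cc1cc(C)c(CSc2ncnc3c2ncn3[C@@H]2O[C@H](CO)[C@@H](O)[C@H]2O)c(C)c1` differs from compound 2 by 2,4,6-trimethylphenyl in place of 3-(trifluoromethyl)phenyl on a saturated chain carbon bound to a sulfur. Among the measured compounds shown here, the only measured step bearing on this change is a 1.7-fold higher number from compound 1 to compound 2 (0.22 log units; within the scatter), an exchange of one aryl for another at the same place without leaving the scatter. For the measured compounds named here, no step covers a ring carrying three methyl groups. Compound 3 is therefore expected at 20 nM (range 6 nM to 70 nM), a step of a 1.0-fold higher number from compound 2 to compound 3 (0.02 log units; within the scatter) not expected to exceed the scatter.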

Compound 3, inhibition constant: 1910 nM
The estimate for compound 3 lay 96-fold (1.98 log units) below the measured number, and the stated range ends below it.
By their numbers in this assay, from the lowest: compounds 1 and 2 (each within the scatter of the next); then compound 3.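

In this assay, the step of a 100-fold higher number from compound 2 to compound 3 (2.00 log units; beyond the scatter) and that of a 170-fold higher number from compound 1 to compound 3 (2.22 log units; beyond the scatter) show that this place, on a saturated chain carbon bound to a sulfur, does not accept every aryl group alike. The level pair of 4-bromophenyl and 3-(trifluoromethyl)phenyl gave no sign of this, and 2,4,6-trimethylphenyl still carries one six-membered aromatic ring of carbon only and no net charge. Nothing available explains the large step.

Still open, going by these compounds, is whether a phenyl ring with a single methyl group stands level with compounds 1 and 2 or follows compound 3. Also open, on these data alone, is how an amine on the ring, or a longer chain at this place, would fare.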